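This account rests on a few compounds, and the source may have more. Where it says the series, first, only, none or still open, it means among the compounds named here.

Of the compounds shown here, two sharing one core have been tested in an ADME assay on HepG2 cells (Homo sapiens) for cytotoxicity, read by CellTiter-Glo and resazurin assay, with a stated time of 72 h; on this read-out higher numbers stand for an effect only at larger amounts of compound and lower numbers for an effect already at smaller amounts. Compound 1, `CCOC(=O)CCCCCOc1cccc(CN(C(=O)c2ccc(-c3cnc(OC)nc3OC)cc2)C(C)C)c1`, reached only a limit of the assay: in this assay compound 1 gives > 26000 nM. Compound 2, `CCOC(=O)CCCCCOc1cccc(CN(C(=O)c2ccc(-c3cccc(OC)c3)cc2)C(C)C)c1`, likewise reached only a limit: in this assay compound 2 gives > 21000 nM. The step that the two limits leave unreadable from compound 1 to compound 2 therefore has no readable size, since both ends rest on limits (the limit of > 26000 nM in this assay, at which 1 of the 2 values shown sits, and (the limit of > 21000 nM in this assay, at which 1 of the 2 values shown sits)). So compound 2 stands only at a limit in this assay, with no number behind it.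

Compound 3, `CCOC(=O)CCCCCOc1cccc(CN(C(=O)c2ccc(-c3cccc(CC(=O)O)c3)cc2)C(C)C)c1`, is not yet measured. It differs from compound 2 by carboxymethyl in place of methoxy on an aromatic carbon. Within the data shown here, no measured step touches this change, and the one step known cannot be sized, so no shift beyond the scatter is expected in either direction. The step from compound 2 to compound 3 is expected to be a step that the limit leaves unreadable from compound 2 to compound 3. Compound 3 is expected to give about 30000 nM in this assay, most likely between 10000 nM and 100000 nM, probably again as a limit only.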

Compound 3, half-maximal effective concentration: > 26000 nM
Compound 3: no number, only a limit; the forecaster's own chance of this, stated with the estimate: 85%; the middle value lies beyond the limit too.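

In this assay, among these compounds, compound 1, compound 2 and compound 3 all rest on limits rather than numbers, and no step among them can be read. The compounds shown leave open at what concentration any of them would show an effect, and whether these changes shift it at all.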